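Cytotoxicity notes on replacing the nitrophenyl ether

The source may report more compounds than this note shows. Statements on the series, on what has been measured and on what is new or still open speak of the compounds shown alone.

Compound 2 `O=[N+]([O-])c1ccc(Oc2ccccc2-c2ccc(S(=O)(=O)NCCNC(=S)Nc3cc(C(F)(F)F)cc(C(F)(F)F)c3)s2)cc1` carries a 4-nitrophenyl on an oxygen on an aromatic ring, and compound 1 `O=S(=O)(NCCNC(=S)Nc1cc(C(F)(F)F)cc(C(F)(F)F)c1)c1ccc(-c2ccccc2OCc2cccc(O)c2)s1` carries a 3-hydroxybenzyl there instead. In an ADME assay on HEK-293T cells (Homo sapiens) for cytotoxicity, read by CCK-8 assay, with a stated time of 48 h (a higher number here means a weaker inhibitor, a lower number a stronger inhibitor), compound 2 gives 6000 nM. Compound 1 reaches only the limit of > 20000 nM in this assay. The change 3-hydroxybenzyl in place of 4-nitrophenyl on an oxygen on an aromatic ring therefore gives an at least 3.3-fold higher number from compound 2 to compound 1 (0.52 log units; beyond the scatter), a reading that rests on (the limit of > 20000 nM in this assay, at which 2 of the 3 values shown sit). Compound 3 `COc1ccc(NC(=O)NCCNS(=O)(=O)c2ccc(-c3ccccc3Oc3ccc([N+](=O)[O-])cc3)s2)cc1` shares the 4-nitrophenyl ether with compound 2, but the difference between the two cores is not broken down here. Compound 3 sits at the limit of > 20000 nM. Compound 4 `COc1ccc(NC(=O)NCCNS(=O)(=O)c2ccc(-c3ccccc3OCc3cccc(O)c3)s2)cc1` carries the same change, (3-hydroxybenzyl in place of 4-nitrophenyl on an oxygen on an aromatic ring). The earlier step of an at least 3.3-fold higher number from compound 2 to compound 1 (0.52 log units; beyond the scatter) did not lower the number. Compound 4 is therefore expected to remain at the limit, with the step that the limit leaves unreadable from compound 3 to compound 4 expected. The estimate for compound 4 is 30000 nM, between 15000 nM and 80000 nM.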

Compound 4, half-maximal inhibitory concentration: > 20000 nM
Compound 4: only a limit was reported; the forecaster's own chance of this, stated with the estimate: 85%; the middle value is on the limit's open side.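

No new step can be read, since compound 3 and compound 4 both stand only as limits in this assay. Going by these compounds, whether 3-hydroxybenzyl changes the number at all on the core of compound 3 stays open.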